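The source may report more compounds than this note shows. Statements on the series, on what has been measured and on what is new or still open speak of the compounds shown alone.

Measured so far in a functional assay on K562 cells (Homo sapiens) for inhibition, read by CCK-8 assay, with a stated time of 72 h; on this read-out lower numbers stand for stronger inhibition and higher numbers for weaker inhibition:
- Compound 1 `O=C(/C=C/c1cccnc1)NCCCCCc1ccc(S(=O)(=O)Nc2ccccc2)cc1`: 146 nM
- Compound 2 `Cc1cccc(NS(=O)(=O)c2cccc(CCCCCCNC(=O)/C=C/c3cccnc3)c2)c1`: 4.78 nM

Compound 2 has the lower of the two numbers, so it is the stronger inhibitor in this assay, and its gap to compound 1 lies beyond the scatter. Compound 3 `O=C(/C=C/c1cccnc1)NCCCCCCc1cccc(S(=O)(=O)Nc2ccc(C(F)(F)F)cc2)c1` keeps the rest of compound 2 and changes one group: 4-(trifluoromethyl)phenyl in place of 3-methylphenyl on a sulfonamide nitrogen. In words, 4-(trifluoromethyl)phenyl stands in place of 3-methylphenyl on a sulfonamide nitrogen. Among the measured compounds shown here, no measured pair here differs at this group alone, so the data give no direct guide to this change. A cautious expectation is therefore a small move toward a higher number in this assay, perhaps not beyond the scatter. The estimated change is a 1.9-fold higher number from compound 2 to compound 3 (0.27 log units; within the scatter). For compound 3 the expected value is 9 nM, with an estimated range of 2.5 nM to 35 nM.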

Compound 3, half-maximal inhibitory concentration: 44.9 nM
Compound 3: the middle estimate sits 5.0-fold (0.70 log units) below what was measured; measured number above the stated range.
By their numbers in this assay, from the lowest: compound 2; then compound 3; then compound 1.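

In this assay, placing 4-(trifluoromethyl)phenyl in place of 3-methylphenyl on a sulfonamide nitrogen gives a 9.4-fold higher number from compound 2 to compound 3 (0.97 log units; beyond the scatter) and so weakens inhibition by more than the usual scatter. This shows that inhibition responds to what is carried on this ring, even though the ring itself stays a six-membered aromatic ring of carbon only and the rest of the molecule is unchanged. Nothing at hand explains why this change weakens inhibition, so the step stands as an observation only.

The change swaps the group on the ring and also its place on that ring, and the compounds shown cannot separate these two differences. A 3-(trifluoromethyl)phenyl or a 4-methylphenyl group on the same nitrogen would tell them apart.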